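The source may hold more compounds than are shown below. What is called first, only, known or untested is meant among the compounds shown, and "the series" means these compounds.

The compounds share the core shown in compound 2 `CC(C)Nc1nc(Nc2ccc(N3CCN(C)CC3)cc2)ncc1/N=C/c1cccs1`, which in a functional assay on HeLa cells (Homo sapiens) for antiproliferative activity, read by MTT assay (a higher number here means a weaker inhibitor, a lower number a stronger inhibitor), gives 77100 nM. Compound 1 `CC(C)Nc1nc(Nc2ccc(N3CCN(C)CC3)cc2)ncc1/N=C/c1ccccc1` differs from it only at the group on the carbon with a double bond to nitrogen, where it carries phenyl in place of thiophen-2-yl. In this assay compound 1 gives only a limit of the assay, > 100000 nM. The step of an at least 1.2-fold lower number from compound 1 to compound 2 (0.11 log units; that floor lies within the scatter) is therefore bounded on one side, as the limit of > 100000 nM in this assay, at which 1 of the 2 values shown sits, shows. Among the values given, compound 2 holds the only finite number; the other value is a limit. Compound 3 `CC(C)Nc1nc(Nc2ccc(N3CCN(C)CC3)cc2)ncc1/N=C/c1ccc(C(F)(F)F)cc1` carries 4-(trifluoromethyl)phenyl in place of thiophen-2-yl on a carbon with a double bond to nitrogen. Going by the values given here, the only measured step that touches this position is the exchange of phenyl for thiophen-2-yl, whose size is at least small with a floor inside the scatter, so no step beyond the scatter is expected here either, with a real chance that the assay again returns only a limit. Compound 3 is therefore estimated in this assay at 100000 nM, with an expected range from 40000 nM to 250000 nM. The expected step is a 1.3-fold higher number from compound 2 to compound 3 (0.11 log units; within the scatter).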

Compound 3, half-maximal inhibitory concentration: > 100000 nM
Compound 3: only a limit was reported; the forecaster's own chance of this, stated with the estimate: 50%; the middle value sits exactly at the limit.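

With 4-(trifluoromethyl)phenyl on the carbon with a double bond to nitrogen, compound 3 also returns only a limit of the assay in this assay, > 100000 nM. Exchanging thiophen-2-yl for this larger group gives an at least 1.2-fold higher number from compound 2 to compound 3 (0.11 log units; that floor lies within the scatter), so the size of the change is bounded on one side only, and its floor does not separate the two compounds. The step between compound 1 and compound 3, trifluoromethyl in place of hydrogen on an aromatic carbon, cannot be read, and the two six-membered aromatic rings of carbon only therefore cannot be ranked against each other: the limit of > 100000 nM in this assay, at which 2 of the 3 values shown sit.

The compounds shown leave open how far compound 1 and compound 3 actually lie from the limit, and whether thiophen-2-yl holds any real advantage over phenyl in this assay. They also leave open whether an amine or a carboxylic acid on the aromatic ring at this carbon, or a furan-2-yl group in place of thiophen-2-yl, would give a finite number well clear of that of compound 2, 77100 nM.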